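Phenyl to methyl on a shared core, working notes

The compounds below may be only part of what the source reports. "The series", "measured", "known", "first", "only" and "open" are said of these compounds alone.

Measured so far, in a functional assay on the whole organism with Rattus norvegicus as the target, at a dose of 100 mg/kg; on this read-out higher numbers stand for more inhibition at the one dose given (going by the name of the read-out) and lower numbers for less inhibition:
compound 1, `CCC/N=C(/NC#N)NCCCn1nc(-c2ccccc2)ccc1=O`, gives 52.9%
compound 2, `CCC/N=C(/NC#N)NCCCn1nc(C)ccc1=O`, gives 17.5%
compound 3, `C/N=C(\S)NCCCn1nc(-c2ccccc2)ccc1=O`, gives 38.9%

Compound 1 and compound 3 share a core and differ on the amine nitrogen: a group of 4 heavy atoms (2 carbon, 1 nitrogen, 1 sulfur; no ring) in place of a group of 8 heavy atoms (5 carbon, 3 nitrogen; no ring), on an amine nitrogen. That exchange costs a number 14 percentage points lower from compound 1 to compound 3 (beyond the scatter) in this assay. Compound 2 differs from compound 1 by methyl in place of phenyl on an aromatic carbon, which makes a number 35.4 percentage points lower from compound 1 to compound 2 (beyond the scatter), the largest step among these three. Compound 3 stands second of the three, with compound 1 higher and compound 2 lower, both beyond the scatter.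

Compound 4, `C/N=C(\S)NCCCn1nc(C)ccc1=O`, has not been measured. It differs from compound 3 by methyl in place of phenyl on an aromatic carbon. Set against the step from compound 1 to compound 2 this is the same kind of change, not the same: the place is described as meta to a group of 8 heavy atoms for compound 3, where for compound 1 it is described as meta to a large group. In both the group that leaves is phenyl and the group that enters is methyl, on the aromatic carbon next to the ring nitrogen.

Among the measured compounds shown here, the step from compound 3 to compound 4 in this assay is expected to be a number 32.9 percentage points lower from compound 3 to compound 4 (beyond the scatter), resting on the single earlier instance, which gave a number 35.4 percentage points lower from compound 1 to compound 2 (beyond the scatter), and on compound 3 starting from a lower value, 38.9%, so that the read-out cannot fall as far before it reaches the bottom of the scale. Compound 4 is therefore estimated at 6%, with a range from 0% to 22%. This rests on one precedent only; a second instance would be needed before calling it a pattern.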

Compound 4, a percentage reported as inhibition, in the whole organism at one dose (the size of the read-out at that dose, not a potency): -8.2%
The estimate for compound 4 lay 14.2 percentage points above the measured number; measured number below the stated range.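

In this assay, methyl in place of phenyl on the aromatic carbon gives a number 47.1 percentage points lower from compound 3 to compound 4 (beyond the scatter), and the two instances of this change cannot be told apart in size: the same change on two cores in this assay, a number 35.4 percentage points lower (beyond the scatter) from compound 1 to compound 2 and a number 47.1 percentage points lower (beyond the scatter) from compound 3 to compound 4, 11.7 percentage points apart, within the scatter of two such steps. The change therefore carries from the core of compound 1 to the core of compound 3 in direction and, within the scatter, in size, with the phenyl compound standing higher in both pairs. This shows no more than two matched pairs at a single dose in one whole-organism read-out, so it does not establish the same step on any other core, and it gives no reason for the loss.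

The compounds shown leave open whether the drop follows from losing the phenyl ring itself or would also appear with other groups at this place, such as ethyl, benzyl or a pyridine ring. Also open, going by these compounds, is whether the step keeps its size with a longer chain in place of the present link to the ring nitrogen, or with a carboxylic acid or an amine added to the phenyl ring.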